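This account rests on a few compounds, and the source may have more. Where it says the series, first, only, none or still open, it means among the compounds named here.

Measured so far in a functional assay on the whole organism (muscle tissue) with Rattus norvegicus as the target; a higher number here means a larger maximal response, a lower number a smaller maximal response:
- compound 1 `CCCNC(=O)C1=CC(C)(C)Oc2ccc([N+](=O)[O-])cc21`: 74.1%
- compound 2 `CCCCNC(=O)C1=CC(C)(C)Oc2ccc([N+](=O)[O-])cc21`: 83.2%
- compound 3 `C#CCNC(=O)C1=CC(C)(C)Oc2ccc([N+](=O)[O-])cc21`: 80.2%

Compound 3 stands within the usual scatter of both other numbers. Against compound 2 the step is a number 3 percentage points lower from compound 2 to compound 3 (within the scatter), and against compound 1 it is a number 6.1 percentage points higher from compound 1 to compound 3 (within the scatter). The remaining pair, compound 1 and compound 2, differs by a number 9.1 percentage points higher from compound 1 to compound 2 (within the scatter). None of the three numbers is therefore separated from another beyond the scatter.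

Compound 4 `CC1(C)C=C(C(=O)NCCC#N)c2cc([N+](=O)[O-])ccc2O1` is the unmeasured member of the series. Its difference from compound 3 is cyanomethyl in place of ethynyl on a saturated chain carbon bound to an amide-type nitrogen.

Two of the measured steps sit at the same place, on a saturated chain carbon bound to an amide-type nitrogen: the step of a number 6.1 percentage points higher from compound 1 to compound 3 (within the scatter) and the step of a number 3 percentage points lower from compound 2 to compound 3 (within the scatter). Both stay within the scatter, and so does the step of a number 9.1 percentage points higher from compound 1 to compound 2 (within the scatter) further along the chain. On these numbers the replacement of ethynyl by cyanomethyl in compound 4 is expected to produce no step beyond the scatter in this assay, in either direction. The step from compound 3 that this expectation means is estimated as a number 1.2 percentage points lower from compound 3 to compound 4 (within the scatter). For compound 4 the estimated value in this assay is 79%, with a range from 66% to 92%.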

Compound 4, intrinsic activity: the largest response reached, in percent of the reference agonist's: 73.1%
Estimate against measurement, compound 4: 5.9 percentage points above, and the stated range covers the measured number.
By their numbers in this assay, from the lowest: compounds 4, 1, 3 and 2 (each within the scatter of the next, the first and the last beyond it).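

In this assay, for the compounds shown here, the change to a cyano-ended chain produces the first step beyond the scatter, a modest one: with cyano in place of ethyl on a saturated chain carbon, two bonds along the chain from an amide-type nitrogen, the data show a number 10.1 percentage points lower from compound 2 to compound 4 (beyond the scatter). The other two comparisons do not separate the compounds, with a number 7.1 percentage points lower from compound 3 to compound 4 (within the scatter) for propargyl to 2-cyanoethyl and a number 1 percentage points lower from compound 1 to compound 4 (within the scatter) for cyano in place of methyl, so this chain position accepts the nitrile without a step beyond the scatter against either of those two neighbours, and only the butyl amide stands apart from it. No available evidence bears on why this one pair separates while the others do not.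

The compounds shown leave open whether an amine or a carboxylic acid in place of the cyano group would stay within the scatter of these numbers, and whether a longer chain carrying the nitrile would match compound 2 or compound 4. They also leave open how far a ring such as cyclopropyl or phenyl on the amide nitrogen would be accepted in place of these open chains.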